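Swapping the Methyl-Bearing Benzyl Group for a Difluorinated One

This account rests on a few compounds, and the source may have more. Where it says the series, first, only, none or still open, it means among the compounds named here.

Compound 1 `O=[N+]([O-])c1ccccc1CSc1nnc(-c2ccc3c(c2)OCCO3)n1-c1ccccc1` and compound 2 `Cc1ccccc1CSc1nnc(-c2ccc3c(c2)OCCO3)n1-c1ccccc1` share one core and differ only in the group carried on the benzyl ring. In a functional assay on BGC-823 cells (Homo sapiens) for antiproliferative activity, read by MTT assay, with a stated time of 24 h (a higher number here means a weaker inhibitor, a lower number a stronger inhibitor), compound 1 gives 26500 nM. In this assay compound 2 gives > 100000 nM, which is a limit of the assay rather than a number. The step of an at least 3.7-fold higher number from compound 1 to compound 2 (0.57 log units; beyond the scatter) is known only as a lower bound because one of the two values sits at the limit of > 100000 nM in this assay, at which 1 of the 2 values shown sits. So compound 2 stands at the weak end of what has been measured, beyond the point the assay can resolve.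

Compound 3 `Fc1ccc(CSc2nnc(-c3ccc4c(c3)OCCO4)n2-c2ccccc2)c(F)c1` carries 2,4-difluorophenyl in place of 2-methylphenyl on a saturated chain carbon bound to a sulfur. For the measured compounds named here, no measured step covers this exchange of one benzyl ring for another; the only step seen, an at least 3.7-fold higher number from compound 1 to compound 2 (0.57 log units; beyond the scatter), shows that changing a single group on that ring can move the number at least modestly. Compound 3 is therefore expected to land between the value of compound 1 and the limit of compound 2, giving an estimated step of an at least 1.6-fold lower number from compound 2 to compound 3 (0.22 log units; that floor lies within the scatter). Compound 3 is estimated at 60000 nM, within a range from 15000 nM to 300000 nM.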

Compound 3, half-maximal inhibitory concentration: > 100000 nM
Compound 3 ended at the assay's limit; the forecaster's own chance of this, stated with the estimate: 45%; at least 1.6-fold (0.22 log units) between middle value and limit.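

Replacing 2-nitrophenyl with 2,4-difluorophenyl on a saturated chain carbon bound to a sulfur gives an at least 3.7-fold higher number from compound 1 to compound 3 (0.57 log units; beyond the scatter). This adds a second, different ring that fails to reach a readable number in this assay, so the change from compound 1 has now been tried with both a methyl group and two fluorine atoms, and both lead to the same limit of the assay. Among these three compounds, only compound 1, with its nitro group, gives an actual number, and the step between compound 2 and compound 3 cannot be read because neither value is more than a limit: the limit of > 100000 nM in this assay, at which 2 of the 3 values shown sit.

The compounds shown leave open whether other groups on this benzyl ring, such as an amine, a carboxylic acid or a nitrile, would also give a readable number, or whether the nitro group is alone in doing so. They also leave open how far past the limit compound 2 and compound 3 truly lie, and whether a change to the shared core would alter this picture.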